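Swapping the sulfonyl heteroaryl ring in compound 1

The source may report more compounds than this note shows. Statements on the series, on what has been measured and on what is new or still open speak of the compounds shown alone.

Compound 1 `Cn1cnnc1S(=O)(=O)N1CCC(CNC(=O)c2ccc(Cl)cc2Cl)(CC2CC2)CC1` is the weakest of the three measured compounds in an assay on JAR cells for inhibition of sodium- and chloride-dependent glycine transporter 1 (Homo sapiens), read by scintillation counting, with a stated time of 3 h (on this read-out higher numbers stand for weaker inhibition and lower numbers for stronger inhibition), where compound 1 gives 124 nM. Compound 2 `Cn1cc(S(=O)(=O)N2CC(CNC(=O)c3ccc(Cl)cc3Cl)(c3ncccc3F)C2)cn1` gives 2.95 nM and compound 3 `Cn1cc(S(=O)(=O)N2CC(CNC(=O)c3ccc(Cl)cc3Cl)(CC3CC3)C2)cn1` gives 3.62 nM, and both stand well beyond the scatter below compound 1.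

Compound 4 `Cn1cc(S(=O)(=O)N2CCC(CNC(=O)c3ccc(Cl)cc3Cl)(CC3CC3)CC2)cn1` is compound 1 with a single change: 1-methyl-1H-pyrazol-4-yl in place of 4-methyl-4H-1,2,4-triazol-3-yl on a sulfonyl sulfur. Among the measured compounds shown here, the only measured step, a 1.2-fold higher number from compound 2 to compound 3 (0.09 log units; within the scatter), concerns a different position, the cyclopropylmethyl against the 3-fluoropyridin-2-yl on a saturated ring carbon, so it does not address the sulfonyl heteroaryl swap directly. Compound 3 carries the same 1-methyl-1H-pyrazol-4-yl sulfonyl and the same cyclopropylmethyl as compound 4, but on a different saturated core than compound 1 and compound 4, so the gap between compound 1 and compound 3 mixes the heteroaryl change with the core change and cannot be assigned to either alone.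

On that basis compound 4 is expected to improve on compound 1, with an estimated step of a 3.1-fold lower number from compound 1 to compound 4 (0.49 log units; beyond the scatter), but by less than the full gap to compound 3. The estimate for compound 4 in this assay is 40 nM, with a range from 10 nM to 160 nM.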

Compound 4, half-maximal inhibitory concentration: 10.4 nM
Estimate against measurement, compound 4: 3.8-fold (0.59 log units) above; low and high end bracket the measured number.
By their numbers in this assay, from the lowest: compounds 2 and 3 (each within the scatter of the next); then compound 4; then compound 1.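

Holding the shared core and the cyclopropylmethyl fixed, 1-methyl-1H-pyrazol-4-yl in place of 4-methyl-4H-1,2,4-triazol-3-yl on a sulfonyl sulfur gives in this assay a 12-fold lower number from compound 1 to compound 4 (1.08 log units; beyond the scatter) and so shows on its own that the group at this position strongly affects the read-out. The two groups are closely matched: each is a five-membered aromatic ring of 6 heavy atoms with no net charge, while the entering ring has 2 hetero atoms in place of 3 and 2 hydrogen-bond acceptors in place of 3, so a small change in atoms goes with a large step. Among the compounds shown here, nothing available here explains why this exchange moves the number so far.

On these data alone, whether the same exchange gives a step of similar size on the core of compound 2 or compound 3 remains open. Also open, as far as these compounds go, is how other groups on the sulfonyl sulfur would read, such as a plain methyl, a phenyl ring or a 1-methyl-1H-imidazol-4-yl ring.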